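The source may report more compounds than this note shows. Statements on the series, on what has been measured and on what is new or still open speak of the compounds shown alone.

Of the compounds shown here, two have numbers so far. Compound 1 `O=c1cc(-c2ccccc2)oc2cccc(OCCCCCCCN3CCC(O)CC3)c12` gives 65 nM in an assay on isolated protein (Cavia porcellus) with Sigma non-opioid intracellular receptor 1 (Homo sapiens) as the target, read by radioligand binding; a higher number here means a weaker inhibitor, a lower number a stronger inhibitor. Compound 2 `O=c1cc(-c2cccnc2)oc2ccc(OCCCCCCN3CCC(O)CC3)cc12` gives 210 nM in this assay. Among the measured compounds shown here, compound 2 therefore stands highest of the two numbers, with compound 1 as its only neighbour and the lower one; the two values differ beyond the scatter, but the two structures differ in more than one place, so no single step can be read from them. Compound 3 `O=c1cc(C2CCCCC2)oc2ccc(OCCCCCCN3CCC(O)CC3)cc12` has not yet been measured. It differs from compound 2 in one place: cyclohexyl in place of pyridin-3-yl on an aromatic carbon. For the measured compounds named here, no pair of measured compounds covers this exchange. The change from compound 2 to compound 3 is expected to give a modest move toward a lower number, estimated as a 1.9-fold lower number from compound 2 to compound 3 (0.28 log units; within the scatter), and it could still fall within the scatter. For compound 3 the expected value in this assay is 110 nM, within a range from 35 nM to 350 nM.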

Compound 3, half-maximal inhibitory concentration: 46 nM
Estimate against measurement, compound 3: 2.4-fold (0.38 log units) above; the range from low to high includes it.
By their numbers in this assay, from the lowest: compounds 3 and 1 (each within the scatter of the next); then compound 2.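

In this assay, among the compounds shown here, cyclohexyl in place of pyridin-3-yl on the aromatic carbon next to the ring oxygen gives a 4.6-fold lower number from compound 2 to compound 3 (0.66 log units; beyond the scatter), the first change that can be read at a single place. This position therefore tolerates a non-aromatic ring of carbon only, with no hydrogen-bond acceptor, and the number falls beyond the scatter. Nothing at hand bears on the reason for this step.

The exchange removes the aromatic ring and the ring nitrogen together, so the step cannot be assigned to either alone; phenyl at this position on an otherwise unchanged compound 3 would separate them, since compound 1 carries phenyl but differs from compound 3 in more than one place. From the compounds shown here alone, how the number responds to ring size, for example with cyclopentyl or cycloheptyl, also remains open.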